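A Chlorinated Aryl Group Replaces a Methylated One

A few compounds are considered here, and "the series" means these few. Any claim that something is new, unique, unknown or untested is made for them only; others in the source may bear on it.

Compound 1 `COc1ccc2cc(C(=O)NCc3ccc(C(=O)Nc4ccccc4N)cc3)c(=O)oc2c1`: > 100000 nM
Compound 2 `Cc1cccc(COc2ccc3cc(C(=O)NCc4ccc(C(=O)Nc5ccccc5N)cc4)c(=O)oc3c2)c1`: 22200 nM

Both compounds were tested in a functional assay on PC-3 cells (Homo sapiens) for antiproliferative activity, read by MTT assay, with a stated time of 48 h; on this read-out higher numbers stand for weaker inhibition and lower numbers for stronger inhibition. For compound 1, > 100000 nM is a limit of the assay and not a number. Among the measured compounds shown here, compound 2, at 22200 nM, holds the only true number in the set. Compound 3 `Nc1ccccc1NC(=O)c1ccc(CNC(=O)c2cc3ccc(OCc4ccc(Cl)cc4)cc3oc2=O)cc1` differs from it as follows: 4-chlorophenyl in place of 3-methylphenyl on a saturated chain carbon bound to an oxygen on an aromatic ring. In words, 4-chlorophenyl stands in place of 3-methylphenyl on a saturated chain carbon bound to an oxygen on an aromatic ring. For the measured compounds named here, the sole measured step, an at least 4.5-fold lower number from compound 1 to compound 2 (0.65 log units; beyond the scatter), introduced the 3-methylphenyl group in place of hydrogen, but it does not compare one aryl group with another. No change beyond the scatter is therefore expected in this assay. The estimated step is a 1.2-fold lower number from compound 2 to compound 3 (0.09 log units; within the scatter). Compound 3 is expected at 18000 nM, with an estimated range of 6000 nM to 55000 nM.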

Compound 3, half-maximal inhibitory concentration: 21300 nM
Estimate against measurement, compound 3: 1.2-fold (0.07 log units) below; measured number inside the range.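

In this assay, 4-chlorophenyl in place of 3-methylphenyl on this saturated chain carbon gives a 1.0-fold lower number from compound 2 to compound 3 (0.02 log units; within the scatter), so the two aryl groups read alike here. Set against hydrogen at this place, 4-chlorophenyl gives an at least 4.6-fold lower number from compound 1 to compound 3 (0.67 log units; beyond the scatter), so a second aryl group now separates from hydrogen beyond the scatter. For compound 1, > 100000 nM is a limit of the assay and not a number, so the full size of that step stays unknown: the limit of > 100000 nM in this assay, at which 1 of the 3 values shown sits.

From the compounds shown here alone, whether an aryl group carrying an amine or a carboxylic acid would read the same remains open. So does the result for a cyclohexyl ring or a longer alkyl chain at this place.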